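The compounds below may be only part of what the source reports. "The series", "measured", "known", "first", "only" and "open" are said of these compounds alone.

Compound 1, `OC[C@H]1O[C@@H](n2cnc3c(COc4ccccc4)ncnc32)[C@H](O)[C@@H]1O`, in a functional assay on Huh-7 cells (Homo sapiens) for cytotoxicity, read by MTT assay, with a stated time of 3 days; a lower number here means that less compound is tolerated, a higher number that more compound is tolerated: > 100000 nM.
Compound 2, `CN(Cc1ncnc2c1ncn2[C@@H]1O[C@H](CO)[C@@H](O)[C@H]1O)c1ccccc1`, in this assay: 21000 nM.
Compound 3, `O=C1CCCN1Cc1ncnc2c1ncn2[C@@H]1O[C@H](CO)[C@@H](O)[C@H]1O`, in this assay: 45000 nM.

Compound 1 gives only a limit and no number, as the limit of > 100000 nM in this assay, at which 1 of the 3 values shown sits, states. Of the two actual numbers, compound 2 gives the lowest, so the cells tolerate the smallest amount of it, and its nearest neighbour is compound 3. Compound 4, `O=C(O)CNCc1ncnc2c1ncn2[C@@H]1O[C@H](CO)[C@@H](O)[C@H]1O`, has not yet been measured in this assay. It differs from compound 2 in one place: (carboxymethyl)amino in place of methyl(phenyl)amino on a saturated chain carbon bound to an aromatic carbon. For the measured compounds named here, two measured steps touch the same spot. an at least 4.7-fold lower number from compound 1 to compound 2 (0.67 log units; beyond the scatter), and a 2.1-fold higher number from compound 2 to compound 3 (0.33 log units; beyond the scatter); whenever methyl(phenyl)amino sits on that carbon, less compound is tolerated than with phenoxy or 2-oxopyrrolidin-1-yl there. Taking methyl(phenyl)amino away again, this time for (carboxymethyl)amino, is therefore expected to raise the number. For compound 4 a modest step of a 2.9-fold higher number from compound 2 to compound 4 (0.46 log units; beyond the scatter) is expected, with a real chance that the result is once more only a limit. Compound 4 is estimated at 60000 nM in this assay, expected between 20000 nM and 200000 nM.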

Compound 4, half-maximal cytotoxic concentration: > 100000 nM
Compound 4: a limit, no number; the forecaster's own chance of this, stated with the estimate: 40%; middle value at least 1.6-fold (0.22 log units) from the limit.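

In this assay, replacing the ring-bearing methyl(phenyl)amino on the saturated chain carbon bound to an aromatic carbon with the ring-free (carboxymethyl)amino gives an at least 4.7-fold higher number from compound 2 to compound 4 (0.67 log units; beyond the scatter), and replacing 2-oxopyrrolidin-1-yl with the same group gives an at least 2.2-fold higher number from compound 3 to compound 4 (0.34 log units; beyond the scatter). Compound 4 is the first compound shown with no ring in the group at this position, so reaching the top of the measured range does not depend on the phenoxy group of compound 1. The step between compound 1 and compound 4 cannot be read, and the two can only be said to share a limit rather than a number: the limit of > 100000 nM in this assay, at which 2 of the 4 values shown sit.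

The compounds shown leave open whether the change in compound 4 follows from its carboxylic acid or simply from the loss of the phenyl ring of compound 2, and a plain methylamino group or a methyl ester in place of the acid would separate these two readings. They also leave open whether a longer chain carrying the acid, such as (2-carboxyethyl)amino, would stay at the limit or give a real number.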